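Longer Alkyl Chain on the Aryl Ring and Cytotoxicity

The compounds below may be only part of what the source reports. "The series", "measured", "known", "first", "only" and "open" are said of these compounds alone.

Measured so far in an ADME assay on HEL cells (Homo sapiens) for cytotoxicity, with a stated time of 3 days; on this read-out higher numbers stand for lower toxicity in this test and lower numbers for higher toxicity in this test: compound 1 `CCCc1ccc(C#Cc2cc3cn([C@H]4C[C@H](O)[C@@H](CO)O4)c(=O)nc3o2)cc1` gives 87000 nM. Compound 2 `O=c1nc2oc(C#Cc3ccccc3)cc2cn1[C@H]1C[C@H](O)[C@@H](CO)O1` gives only a limit of the assay, > 570000 nM.

Compound 2 thus stands at the top of the two values shown; of the two, it is the one sitting at the limit of > 570000 nM in this assay, at which 1 of the 2 values shown sits, while compound 1 carries the lower number. Compound 3 `CCCCCc1ccc(C#Cc2cc3cn([C@H]4C[C@H](O)[C@@H](CO)O4)c(=O)nc3o2)cc1` differs from compound 2 by pentyl in place of hydrogen on an aromatic carbon. Going by the values given here, the one measured step that bears on this change is an at least 6.5-fold higher number from compound 1 to compound 2 (0.81 log units; beyond the scatter), which went from a propyl chain to a bare hydrogen. Adding a chain back, now two carbons longer, is expected to move the number the opposite way, and by at least a comparable amount, so that compound 3 should give a measurable number rather than a limit. The expected step is an at least 14-fold lower number from compound 2 to compound 3 (1.15 log units; beyond the scatter). Compound 3 is therefore estimated at 40000 nM, within a range of 10000 nM to 200000 nM.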

Compound 3, minimum cytotoxic concentration: 470000 nM
The estimate for compound 3 lay 12-fold (1.07 log units) below the measured number, and the stated range ends below it.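

In this assay, going from the propyl chain to the pentyl chain at this place on the ring gives a 5.4-fold higher number from compound 1 to compound 3 (0.73 log units; beyond the scatter), so across these two chains the longer one does not carry the lower number. Set against the unsubstituted ring, the pentyl chain shows an at least 1.2-fold lower number from compound 2 to compound 3 (0.08 log units; that floor lies within the scatter), so no real change from adding this chain can be claimed, and the drop seen with propyl does not carry over to pentyl. Compound 2 counts here only as a limit of the assay and not as a number: the limit of > 570000 nM in this assay, at which 1 of the 3 values shown sits.

Going by these compounds, how a butyl chain, or a chain longer than pentyl, would read at this place stays open, as does whether the number follows chain length in any orderly way. Also open, on these data alone, is the reading for a different kind of group there, such as an amine or a carboxylic acid.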